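Notes on an amide change following two measured compounds

This account rests on a few compounds, and the source may have more. Where it says the series, first, only, none or still open, it means among the compounds named here.

Measured so far:
- compound 1, `CC(C)c1cc(C(C)(C)C)cc(-c2cccc(-c3ccccc3)c2)c1CO`: in a functional assay on RKE cells for antagonist activity at Vasoactive intestinal polypeptide receptor 1 (Rattus norvegicus), read by HTRF and cAMP accumulation, with stated times of 10 min and 30 min (on this read-out higher numbers stand for weaker inhibition and lower numbers for stronger inhibition), compound 1 gives 210 nM
- compound 2, `CC(=O)Nc1sc2c(c1C#N)CCCC2`: in this assay compound 2 gives 13000 nM

Compound 2 stands at the highest of the two numbers; compound 1 is the nearest and sits at a markedly lower number, and that gap lies beyond the usual scatter. Among the compounds with values here, the two compounds share no common core, so no step between them is drawn and nothing is read from the pair beyond what the two values show.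

Compound 3, `N#Cc1c(NC(=O)c2ccccc2)sc2c1CCCC2`, is the next one to be measured. Relative to compound 2 the change is phenyl in place of methyl on a carbonyl carbon. Within the data shown here, no comparable step in this assay exists among the measured compounds, so the direction is open. Compound 3 is expected to land roughly where compound 2 does, with a step of a 1.6-fold lower number from compound 2 to compound 3 (0.21 log units; within the scatter) taken as within or near the scatter. The estimate for compound 3 is 8000 nM, within a range of 2000 nM to 30000 nM.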

Compound 3, half-maximal inhibitory concentration: 15000 nM
Beside the measured number, compound 3's estimate is 1.9-fold (0.27 log units) below it; the range from low to high includes it.
By their numbers in this assay, from the lowest: compound 1; then compounds 2 and 3 (each within the scatter of the next).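

On a carbonyl carbon whose other neighbour is an amide-type nitrogen, phenyl in place of methyl gives a 1.2-fold higher number from compound 2 to compound 3 (0.06 log units; within the scatter) in this assay. Within the data shown here, this is the first single-place comparison, and on this read-out it does not separate the two groups, so a phenyl ring is accommodated at this place with no change in the number beyond the scatter. No available evidence bears on this result.

With only methyl and phenyl shown on this carbonyl carbon, it remains open whether a longer alkyl chain, a carboxylic acid, an amine or a substituted phenyl ring there would move the number beyond the scatter. On these data alone, it is also open how the number responds to a change elsewhere on the shared core, such as replacing the nitrile with another group.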